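The source may hold more compounds than are shown below. What is called first, only, known or untested is meant among the compounds shown, and "the series" means these compounds.

Working notes on the series. Among the compounds with values here, in a functional assay on PC-3 cells (Homo sapiens) for inhibition, read by MTT assay, with a stated time of 48 h, tested at 10 uM (a lower number here means less inhibition of growth, a higher number more inhibition of growth at the concentration tested), compound 1 (`Cc1cc(=O)c2c(O)cc(OCc3ccccc3)c([C@H]3CCN(C)C[C@H]3O)c2o1`) gives 41% and compound 2 (`Cc1cc(=O)c2c(O)cc(OCc3ccc(Br)cc3)c([C@H]3CCN(C)C[C@H]3O)c2o1`) gives 17%, the lower of the two numbers measured so far. Compound 3 (`Cc1cc(=O)c2c(O)cc(OCc3ccco3)c([C@H]3CCN(C)C[C@H]3O)c2o1`) is the next to read. It carries furan-2-yl in place of 4-bromophenyl on a saturated chain carbon bound to an oxygen on an aromatic ring.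

Within the data shown here, one measured step bears on this change: a number 24 percentage points lower from compound 1 to compound 2 (beyond the scatter), with bromo in place of hydrogen on an aromatic carbon. That step is modest but beyond the scatter. The bromo is lost again in compound 3, so part or all of that drop may be recovered. Among the measured compounds shown here, no furan-2-yl compound has been measured, however, so the effect of the ring exchange itself is unknown and the range stays wide. In this assay, the expected change is a number 17 percentage points higher from compound 2 to compound 3 (beyond the scatter), a rise of similar or slightly smaller size than the measured drop. For compound 3 the estimated value is 34%, with an expected range of 15% to 54%.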

Compound 3, percent growth inhibition at one concentration: 14%
Compound 3: middle estimate off by 20 percentage points, on the high side, outside the stated range (below it).
By their numbers in this assay, from the lowest: compounds 3 and 2 (each within the scatter of the next); then compound 1.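

In this assay, furan-2-yl in place of 4-bromophenyl on a saturated chain carbon bound to an oxygen on an aromatic ring gives a number 3 percentage points lower from compound 2 to compound 3 (within the scatter), so these two groups cannot be told apart at this position, and a compound without the bromo does not necessarily return to the number of compound 1. Set against phenyl, the same furan-2-yl gives a number 27 percentage points lower from compound 1 to compound 3 (beyond the scatter), so the drop seen earlier is no longer tied to bromo alone: among these three compounds, phenyl stands apart, while 4-bromophenyl and furan-2-yl share the lower level. No measured evidence at hand accounts for this pattern.

Still open, as far as these compounds go, is whether a higher number than that of compound 1 can be reached at this position, for instance with a cyclohexyl ring, a pyridin-3-yl ring or a longer chain such as 2-phenylethyl. Also open, from the compounds shown here alone, is whether the same order of compounds would hold at other concentrations or in other cell lines.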